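Iodinated cyanosulfanyl analogue of the diaryl piperazine series

This account rests on a few compounds, and the source may have more. Where it says the series, first, only, none or still open, it means among the compounds named here.

Compound 2 `[N-]=[N+]=Nc1ccc(CN2CCN(CCCN(c3ccc(F)cc3)c3ccc(F)cc3)CC2)cc1I` gives 242 nM in an assay on isolated protein (strain Sprague-Dawley) for displacement of a labelled ligand from sodium-dependent dopamine transporter (Rattus norvegicus) (a higher number here means a weaker inhibitor, a lower number a stronger inhibitor), the highest of the two numbers measured; its nearest neighbour is compound 1 `N#CSc1ccc(CCCN2CCN(CCCN(c3ccc(F)cc3)c3ccc(F)cc3)CC2)cc1`, which gives 99.8 nM. Compound 3 `N#CSc1ccc(CCCN2CCN(CCCN(c3ccc(F)cc3)c3ccc(F)cc3)CC2)cc1I` differs from compound 2 by 2-(4-(cyanosulfanyl)-3-iodophenyl)ethyl in place of 4-azido-3-iodophenyl on a saturated chain carbon bound to an amine nitrogen in a ring. Within the data shown here, the only measured step, a 2.4-fold higher number from compound 1 to compound 2 (0.38 log units; beyond the scatter), went the other way in a related exchange, so compound 3, which carries the 2-(4-(cyanosulfanyl)phenyl)ethyl motif of compound 1 with an added 3-iodo substitution, is expected to return most of that step, a 2.0-fold lower number from compound 2 to compound 3 (0.30 log units; within the scatter). Compound 3 is therefore estimated at 120 nM (range 45 nM to 320 nM).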

Compound 3, half-maximal inhibitory concentration: 95.5 nM
The estimate for compound 3 lay 1.3-fold (0.10 log units) above the measured number, within the range that was stated.
By their numbers in this assay, from the lowest: compounds 3 and 1 (each within the scatter of the next); then compound 2.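

In this assay, 2-(4-(cyanosulfanyl)-3-iodophenyl)ethyl in place of 4-azido-3-iodophenyl on a saturated chain carbon bound to an amine nitrogen in a ring gives a 2.5-fold lower number from compound 2 to compound 3 (0.40 log units; beyond the scatter). Both groups carry iodo, so this step separates the two groups with iodo held in common. Iodo in place of hydrogen on an aromatic carbon gives a 1.0-fold lower number from compound 1 to compound 3 (0.02 log units; within the scatter), so iodo on this aromatic carbon does not separate compound 1 from compound 3. No evidence explains either result. The compounds shown leave open how an amine or a carboxylic acid in place of iodo would read in this assay.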